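This account rests on a few compounds, and the source may have more. Where it says the series, first, only, none or still open, it means among the compounds named here.

Three compounds share one core and differ only in the group on the aniline ring. Compound 1 `Cc1cnc(Nc2ccc(S(C)(=O)=O)cc2)nc1Nc1nc2ccccc2s1` gives 460 nM in a functional assay on HeLa cells (Homo sapiens) for antiproliferative activity, read by MTT assay, with a stated time of 48 h (a higher number here means a weaker inhibitor, a lower number a stronger inhibitor), compound 2 `Cc1cnc(Nc2ccc([N+](=O)[O-])cc2)nc1Nc1nc2ccccc2s1` gives 34300 nM, and compound 3 `Cc1cnc(Nc2ccc(S(N)(=O)=O)cc2)nc1Nc1nc2ccccc2s1` gives 2800 nM, which is the second highest of the three numbers. The steps are all beyond the scatter: a 75-fold higher number from compound 1 to compound 2 (1.87 log units; beyond the scatter), a 6.1-fold higher number from compound 1 to compound 3 (0.78 log units; beyond the scatter) and a 12-fold lower number from compound 2 to compound 3 (1.09 log units; beyond the scatter). Compound 4 `Cc1cnc(Nc2ccc(Cl)cc2)nc1Nc1nc2ccccc2s1` carries chloro in place of sulfamoyl on an aromatic carbon. Within the data shown here, no measured step swaps in a chloro group, and the three groups already tried give numbers spread over a wide span, so the size of the step in this assay is hard to fix. Compound 4 is expected to give 5000 nM, within 1000 nM to 30000 nM, meaning an estimated 1.8-fold higher number from compound 3 to compound 4 (0.25 log units; within the scatter).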

Compound 4, half-maximal inhibitory concentration: > 50000 nM
Compound 4 was reported as a limit (the forecaster's own chance of this, stated with the estimate: 5%); middle value at least 10-fold (1.00 log units) from the limit.
By their numbers in this assay, from the lowest: compound 1; then compound 3; then compound 2. At a limit, above all of these: compound 4.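

Compound 4 is reported as a limit, not a number: the limit of > 50000 nM in this assay, at which 1 of the 4 values shown sits.

Chloro on this aromatic carbon gives an at least 17-fold higher number from compound 3 to compound 4 (1.25 log units; beyond the scatter) and an at least 100-fold higher number from compound 1 to compound 4 (2.03 log units; beyond the scatter), so both sulfur-bearing groups give far stronger inhibitors than chloro does. The step from nitro reads an at least 1.4-fold higher number from compound 2 to compound 4 (0.16 log units; that floor lies within the scatter), so those two groups cannot be put in order.

The compounds shown leave open how an amine or a carboxylic acid on this carbon would compare with methylsulfonyl. They also leave open whether a longer chain on the sulfonyl sulfur, such as ethyl, would keep the activity of compound 1.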